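This account rests on a few compounds, and the source may have more. Where it says the series, first, only, none or still open, it means among the compounds named here.

Measured so far, in a functional assay on cells (Melanoma cell, Homo sapiens) for cytotoxicity, read by sulforhodamine B assay, with a stated time of 48 h; on this read-out higher numbers stand for weaker inhibition of growth and lower numbers for stronger inhibition of growth:
compound 1 `CN(C)c1ccc(C2CC(c3ccccc3)=NN2C2=NC(=O)/C(=C3\C(=O)Nc4ccccc43)S2)cc1`, which gives 29400 nM;
compound 2 `CN(C)c1ccc(C2CC(c3ccccc3)=NN2C2=NC(=O)/C(=C3\C(=O)Nc4ccc(Br)cc43)S2)cc1`, which gives 460 nM.

Going by the values given here, compound 2 holds the lowest of the two numbers in this assay; its only neighbour is compound 1, and the step of a 64-fold lower number from compound 1 to compound 2 (1.81 log units; beyond the scatter) separates them. Compound 3 `CN(C)c1ccc(C2CC(c3ccccc3)=NN2C2=NC(=O)/C(=C3\C(=O)Nc4ccc(Cl)cc43)S2)cc1` differs from compound 2 in a single place: chloro in place of bromo on an aromatic carbon. Among the compounds with values here, the one measured step that bears on this position is a 64-fold lower number from compound 1 to compound 2 (1.81 log units; beyond the scatter), in which a bromo entering for hydrogen brought the large drop in this assay. Compound 3 keeps a halogen at that position, so most of what that step gained is expected to remain, while a halogen of a smaller count of electrons may not match the bromo fully. The step of a 1.6-fold higher number from compound 2 to compound 3 (0.21 log units; within the scatter) is therefore expected to be modest and, if anything, toward a higher number. For compound 3 the estimate in this assay is 750 nM, within a range from 250 nM to 2500 nM.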

Compound 3, concentration for total growth inhibition: 570 nM
Beside the measured number, compound 3's estimate is 1.3-fold (0.12 log units) above it; the range from low to high includes it.
By their numbers in this assay, from the lowest: compounds 2 and 3 (each within the scatter of the next); then compound 1.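

In this assay, the step of a 1.2-fold higher number from compound 2 to compound 3 (0.09 log units; within the scatter) stays within the scatter, so chloro and bromo on this aromatic carbon cannot be told apart and the earlier gain is not particular to bromo. The step of a 52-fold lower number from compound 1 to compound 3 (1.71 log units; beyond the scatter) is large, as is a 64-fold lower number from compound 1 to compound 2 (1.81 log units; beyond the scatter), so two different halogens now stand against hydrogen at this place, each beyond the scatter. Nothing measured here explains why either halogen has this effect on inhibition of growth. The compounds shown leave open whether the gain belongs to halogens alone, as a methoxy group, a nitro group or an amine at this place would show. They also leave open whether fluoro would go with chloro and bromo, or whether iodo would hold the same level.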